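The compounds below may be only part of what the source reports. "The series", "measured", "known", "first", "only" and "open" are said of these compounds alone.

For the measured compounds named here, compound 1 `FC(F)(F)c1cnc2c(c1)Oc1ccccc1C1=NCCN12` is measured in an assay for inhibition of Amine oxidase [flavin-containing] A (Homo sapiens), read by fluorescence and spectrophotometry, using microsomes, with stated times of 30 min and 20 min (on this read-out higher numbers stand for weaker inhibition and lower numbers for stronger inhibition), at 32000 nM, and compound 3 `CC(C)(C)c1ccc(-c2noc(-c3ccc(C4=NCCN4)cc3)n2)cc1` gives 751 nM in this assay, a lower number than compound 1 shows; no step between the two is worked out here. Compound 2 `c1ccc(OCc2noc(-c3ccc(C4=NCCN4)cc3)n2)cc1` stands apart from both: in this assay compound 2 returns only a limit, > 100000 nM, so no number is known for it, as the limit of > 100000 nM in this assay, at which 1 of the 3 values shown sits, records. The route to compound 4 `Cc1ccc(Cc2noc(-c3ccc(C4=NCCN4)cc3)n2)cc1` is a single change, (4-methylphenyl in place of phenoxy on a saturated chain carbon bound to an aromatic carbon), in words 4-methylphenyl in place of phenoxy on a saturated chain carbon bound to an aromatic carbon. Going by the values given here, since compound 2 has only a limit, no measured step tells how such a change plays out, and compound 3 carries its aryl group without a saturated chain carbon, so it does not settle the question either. The step from compound 2 to compound 4 is expected to be an at least 1.6-fold lower number from compound 2 to compound 4 (0.22 log units; that floor lies within the scatter), a modest gain at best, and may well leave compound 4 at the limit again. For compound 4 the expected value in this assay is 60000 nM, within a range from 15000 nM to 250000 nM.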

Compound 4, half-maximal inhibitory concentration: 55500 nM
For compound 4 the middle estimate is 1.1-fold (0.03 log units) above the measured one; low and high end bracket the measured number.
By their numbers in this assay, from the lowest: compound 3; then compounds 1 and 4 (each within the scatter of the next). At a limit, above all of these: compound 2.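

With 4-methylphenyl on the saturated chain carbon bound to an aromatic carbon, compound 4 gives 55500 nM in this assay, so this position can carry an aryl group and still return a measured number. The change reads as an at least 1.8-fold lower number from compound 2 to compound 4 (0.25 log units; that floor lies within the scatter), and that floor is all that can be said of its size, so the step does not establish a difference beyond the scatter. The true size stays unknown, as compound 2 holds a limit and not a number: the limit of > 100000 nM in this assay, at which 1 of the 4 values shown sits.

The change takes out the oxygen and brings in the methyl together, and the compounds shown cannot tell which of the two matters. Going by these compounds, whether an amine, a carboxylic acid or a longer chain in this place would give a lower number also remains open.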